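The compounds below may be only part of what the source reports. "The series", "measured", "known", "first", "only" and "open" are said of these compounds alone.

Compound 1 `Fc1ccc(-c2nc3ncccn3c2NC2CCCCC2)cc1` in a toxicity assay on A549 cells (Homo sapiens) for cytotoxicity, read by luminescence and CellTiter-Glo, with a stated time of 48 h (a higher number here means that more compound is tolerated, a lower number that less compound is tolerated), gives 100000 nM. Compound 3 `Oc1cccc(-c2nc3ncccn3c2NC2CCCCC2)c1` gives 100000 nM in this assay, and no change at the digits printed from compound 1 to compound 3 (within the scatter). Compound 2 `Clc1ccc(-c2nc3ncccn3c2NC2CCCCC2)cc1` returns only a limit in this assay, > 100000 nM. the limit of > 100000 nM in this assay, at which 1 of the 3 values shown sits, marks the top of what this assay reports. Compound 1 therefore stands level with compound 3 at the digits shown, with compound 2 sitting at the limit. Compound 4 `CN(c1c(-c2ccc(F)cc2)nc2ncccn12)C1CCCCC1` differs from compound 1 by methyl in place of hydrogen on a nitrogen on an aromatic ring. The measured steps of a number no lower from compound 1 to compound 2 (the limit leaves the size open) and a number no higher from compound 2 to compound 3 (the limit leaves the size open) alter only the substituent on an aromatic carbon, not the nitrogen, so none of them bears on this change; all three values sit at or past the top of the range. Compound 4 is expected at 100000 nM, between 30000 nM and 100000 nM. The expected step is no change at the digits printed from compound 1 to compound 4 (within the scatter), no change beyond the scatter.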

Compound 4, half-maximal cytotoxic concentration: > 100000 nM
Compound 4: only a limit was reported; the forecaster's own chance of this, stated with the estimate: 50%; the middle value sits exactly at the limit.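

The nitrogen carrying the cyclohexyl group is the same in compound 1, compound 2 and compound 3, and in this assay cyclohexylamino to cyclohexyl(methyl)amino gives a number no lower from compound 1 to compound 4 (the limit leaves the size open). The size of this step cannot be read. Compound 4 returns only a limit and now sits at the top of the range: the limit of > 100000 nM in this assay, at which 2 of the 4 values shown sit.

On these data alone, whether an ethyl group, a longer chain or an acetyl group on this nitrogen would give a value inside the range stays open. So does the effect of an amine in place of the cyclohexyl ring.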